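The compounds below may be only part of what the source reports. "The series", "measured", "known", "first", "only" and "open" are said of these compounds alone.

Among the measured compounds shown here, in a functional assay on HCT-116 cells (Homo sapiens) for antiproliferative activity, read by MTT assay, with a stated time of 72 h (on this read-out lower numbers stand for stronger inhibition and higher numbers for weaker inhibition), compound 1 `Cc1ccccc1N1CCN(C(=S)SCc2ccc3nc(N)nc(N)c3c2)CC1` gives 11800 nM and compound 2 `Cc1ccc(N2CCN(C(=S)SCc3ccc4nc(N)nc(N)c4c3)CC2)c(C)c1` gives 4070 nM as the lower of the two numbers measured so far. For the measured compounds named here, compound 3 `Nc1nc(N)c2cc(CSC(=S)N3CCN(c4ccc(Cl)cc4)CC3)ccc2n1` shares their core and differs from compound 2 by 4-chlorophenyl in place of 2,4-dimethylphenyl on an amine nitrogen in a ring as its one change, 4-chlorophenyl in place of 2,4-dimethylphenyl on an amine nitrogen in a ring. Going by the values given here, only one measured step bears on this: a 2.9-fold lower number from compound 1 to compound 2 (0.46 log units; beyond the scatter) is a modest gain in potency, made by methyl in place of hydrogen on an aromatic carbon. Among the compounds with values here, compound 3 has no methyl on that ring, but no measured compound carries chlorine, so the data cannot show what that group does. A small move towards a higher number is therefore expected, and the estimated step is a 1.5-fold higher number from compound 2 to compound 3 (0.17 log units; within the scatter) with real uncertainty in its direction. For compound 3 the estimate is 6000 nM with an expected range from 2000 nM to 18000 nM in this assay.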

Compound 3, half-maximal inhibitory concentration: 7380 nM
Compound 3: middle estimate off by 1.2-fold (0.09 log units), on the low side, within the range that was stated.
By their numbers in this assay, from the lowest: compounds 2, 3 and 1 (each within the scatter of the next, the first and the last beyond it).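

In this assay, putting 4-chlorophenyl on the amine nitrogen in place of 2,4-dimethylphenyl gives a 1.8-fold higher number from compound 2 to compound 3 (0.26 log units; within the scatter), and putting it in place of 2-methylphenyl gives a 1.6-fold lower number from compound 1 to compound 3 (0.20 log units; within the scatter). Both steps lie within the scatter, so compound 3 cannot be told apart from either neighbour, even though compound 1 and compound 2 are separated beyond it; a chlorine-bearing phenyl ring with no methyl therefore keeps the number in the same range as the two methylated rings. No measurement available here explains these numbers.

The compounds shown leave open what a plain phenyl ring with no group on it would give, the comparison that would isolate the contribution of the chlorine. On these data alone, whether a methoxy group or a nitrile on that ring, or a pyridine ring in its place, would move the number beyond the scatter also remains open.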